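Fluorine Count on the Aryl Ketone: One Versus Two

The compounds below may be only part of what the source reports. "The series", "measured", "known", "first", "only" and "open" are said of these compounds alone.

The measured compounds:
compound 1, `CC1(C)S[C@@H]2C/C(=C\C(=O)c3ccccc3)C(=O)N2[C@H]1C(=O)OC(c1ccccc1)c1ccccc1`: 73300 nM
compound 2, `CC1(C)[C@H](C(=O)OC(c2ccccc2)c2ccccc2)N2C(=O)/C(=C/C(=O)c3ccc([N+](=O)[O-])cc3)[C@H]2[S+]1[O-]`: 92400 nM
compound 3, `CC1(C)S[C@@H]2/C(=C\C(=O)c3ccc(F)cc3)C(=O)N2[C@H]1C(=O)OC(c1ccccc1)c1ccccc1`: 12100 nM

All three were tested in a functional assay on OE19 cells (Homo sapiens) for cytotoxicity, read by MTT assay, with a stated time of 48 h; a lower number here means a stronger inhibitor, a higher number a weaker inhibitor. Compound 3 gives the lowest number of the three, so it is the strongest inhibitor here. Compound 1, which carries an unsubstituted phenyl on the same carbonyl, gives a higher number, beyond the usual scatter, and compound 2, with a nitro-bearing phenyl and an oxidised sulfur in the core, gives a higher number still. Nothing else about these three can be said from the values alone, since no two of them differ in only one place.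

Compound 4, `CC1(C)S[C@@H]2/C(=C\C(=O)c3cc(F)cc(F)c3)C(=O)N2[C@H]1C(=O)OC(c1ccccc1)c1ccccc1`, keeps the shared core of compound 3 and changes only the aromatic ring on the ketone: 3,5-difluorophenyl in place of 4-fluorophenyl on a carbonyl carbon. For the measured compounds named here, no measured pair shows what adding a second fluorine or moving the fluorine does here, so the direction of the step is open. A small step is expected, most likely within the scatter, and the step from compound 3 to compound 4 is estimated at a 1.3-fold higher number from compound 3 to compound 4 (0.12 log units; within the scatter). Compound 4 is therefore expected to give 16000 nM, with a range from 5000 nM to 50000 nM.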

Compound 4, half-maximal inhibitory concentration: 17600 nM
For compound 4 the middle estimate is 1.1-fold (0.04 log units) below the measured one; the range from low to high includes it.
By their numbers in this assay, from the lowest: compounds 3 and 4 (each within the scatter of the next); then compounds 1 and 2 (each within the scatter of the next).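

For the compounds shown here, the swap of 4-fluorophenyl for 3,5-difluorophenyl on a carbonyl carbon is the first change here that can be read on its own, and in this assay it gives a 1.5-fold higher number from compound 3 to compound 4 (0.16 log units; within the scatter) and so stays within the usual scatter of repeated measurements. This position therefore carries either of these two fluorinated rings with no difference that this cell test can resolve, a statement that holds for this one pair and for no wider pattern. No measurement shown offers an explanation for this result.

Going by these compounds alone, the single step alters the number of fluorines and their placement together, and compound 1, the one compound with an unsubstituted phenyl, differs from the fluorinated compounds in more than one place, so the separate contribution of each fluorine remains open. Also open, on these data alone, is how this position responds to a group of a different kind on the ring, such as a methoxy group, an amine or a carboxylic acid, or to a longer chain in place of the ring.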